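Swapping methyl for 4-chlorophenyl on compound 3

The compounds below may be only part of what the source reports. "The series", "measured", "known", "first", "only" and "open" are said of these compounds alone.

- compound 1 `C=C(C)C(=O)c1ccc(OCc2nc(-c3ccccc3)no2)cc1C`: 6700 nM
- compound 2 `C=C(C)C(=O)c1ccc(OCc2nc(-c3ccc(C(F)(F)F)cc3)no2)c(C)c1C`: 1400 nM
- compound 3 `C=C(CC)C(=O)c1ccc(OCc2nc(C)no2)c(Cl)c1Cl`: 2300 nM

All three compounds were tested in a functional assay on HL-60 cells (Homo sapiens) for inhibition; on this read-out higher numbers stand for weaker inhibition of growth and lower numbers for stronger inhibition of growth. Compound 3 gives 2300 nM, which lies within the scatter of compound 2 and is clearly lower than compound 1, so it inhibits growth more strongly than compound 1 does.

Compound 4 `C=C(CC)C(=O)c1ccc(OCc2nc(-c3ccc(Cl)cc3)no2)c(Cl)c1Cl` is compound 3 with a single change: 4-chlorophenyl in place of methyl on an aromatic carbon. For the measured compounds named here, no two measured compounds differ in only one place, so the size of this swap has not been seen directly. Compound 1 and compound 2 also carry a six-membered aromatic ring at that spot, but they differ from compound 3 elsewhere too, and their values lie well apart, which makes them only a loose guide. A small move towards stronger inhibition is expected, possibly no larger than the scatter. The expected change is a 1.8-fold lower number from compound 3 to compound 4 (0.25 log units; within the scatter). The estimate for compound 4 is 1300 nM, with an expected range of 400 nM to 4000 nM.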

Compound 4, concentration for 50% growth inhibition: 1600 nM
Beside the measured number, compound 4's estimate is 1.2-fold (0.09 log units) below it; measured number inside the range.
By their numbers in this assay, from the lowest: compounds 2, 4 and 3 (each within the scatter of the next); then compound 1.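

In this assay, for the compounds shown here, putting 4-chlorophenyl in place of methyl gives a 1.4-fold lower number from compound 3 to compound 4 (0.16 log units; within the scatter), the first step in this set that isolates a single change, and it lies within the scatter. On this aromatic carbon of the five-membered ring, a group of 7 heavy atoms with a six-membered aromatic ring can therefore stand where a single carbon stood, with no measurable change in growth inhibition. No supporting data explain why this large swap leaves the number within the scatter.

Still open, from the compounds shown here alone, is whether the chlorine on the new ring matters, and whether an amine, a carboxylic acid or a longer chain such as hexyl at this spot would behave the same way. Going by these compounds, the role of the two chlorine atoms on the other ring also stays open: compound 1 and compound 2 differ from compound 3 in more than one place.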